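This account rests on a few compounds, and the source may have more. Where it says the series, first, only, none or still open, it means among the compounds named here.

In a functional assay on CCRF-CEM cells (Homo sapiens), with a stated time of 72 h (a higher number here means a weaker inhibitor, a lower number a stronger inhibitor), compound 3 `O=C1/C(=N\NC(=S)Nc2ccc(Cl)cc2)c2cc(Cl)ccc2N1Cc1ccc(Cl)cc1` gives 68000 nM, the highest of the three numbers recorded. Compound 1 `O=C1Nc2ccc(Cl)cc2/C1=N/NC(=S)Nc1ccc(Cl)cc1` gives 61000 nM, and the two stand within the scatter of each other a 1.1-fold higher number from compound 1 to compound 3 (0.05 log units; within the scatter). Compound 2 `Cc1ccc(CN2C(=O)/C(=N\NC(=S)Nc3ccc(Cl)cc3)c3cc(Cl)ccc32)cc1` gives 18000 nM, the step of a 3.8-fold higher number from compound 2 to compound 3 (0.58 log units; beyond the scatter) being the only one beyond the scatter among the three, while a 3.4-fold lower number from compound 1 to compound 2 (0.53 log units; beyond the scatter) points the same way. Compound 4 `O=C1/C(=N\NC(=S)Nc2ccc(Cl)cc2)c2cc(Cl)ccc2N1Cc1ccc(F)cc1` differs from compound 3 by fluoro in place of chloro on an aromatic carbon. For the measured compounds named here, no measured step exchanges one halogen for another at that place; the nearest precedent, the exchange of a methyl for a chloro, moved the number only modestly. Compound 4 is therefore expected to change little, estimated at 50000 nM (range 22000 nM to 115000 nM), a step of a 1.4-fold lower number from compound 3 to compound 4 (0.13 log units; within the scatter).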

Compound 4, half-maximal inhibitory concentration: 50000 nM
Beside the measured number, compound 4's estimate shows no gap at the digits printed, and the stated range covers the measured number.
By their numbers in this assay, from the lowest: compound 2; then compounds 4, 1 and 3 (each within the scatter of the next).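

For the compounds shown here, exchanging 4-chlorobenzyl for 4-fluorobenzyl, the first halogen exchange at this place, leaves the number in this assay essentially unchanged, a 1.4-fold lower number from compound 3 to compound 4 (0.13 log units; within the scatter). Adding the 4-fluorobenzyl group to the amide-type nitrogen likewise gives no separation, a 1.2-fold lower number from compound 1 to compound 4 (0.09 log units; within the scatter), whereas the exchange of methyl for fluoro does, modestly, a 2.8-fold higher number from compound 2 to compound 4 (0.44 log units; beyond the scatter), so among the groups shown here only methyl stands apart. No measured evidence accounts for this. As far as these compounds go, whether a methoxy group, an amine or a carboxylic acid at this place would fall with methyl or with the two halogens remains open.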